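The source may hold more compounds than are shown below. What is called first, only, known or untested is meant among the compounds shown, and "the series" means these compounds.

Compound 1 `N#Cc1ccc(Cn2nc(-c3cc(Cl)c(NCCO)nc3F)c3ccccc3c2=O)cc1`: 32100 nM
Compound 2 `Cc1nc(-c2ccc(F)nc2F)cn(Cc2ccc(Cl)cc2)c1=O`: > 100000 nM, a limit of the assay
Compound 3 `CNc1ccc(-c2nn(Cc3ccc(C#N)cc3)c(=O)c3ccccc23)c(F)n1`: > 100000 nM, a limit of the assay

These results come from an ADME assay on HepG2 2.2.15 cells (Homo sapiens) for cytotoxicity, read by MTT assay, with a stated time of 8 days; a higher number here means that more compound is tolerated, a lower number that less compound is tolerated. For the measured compounds named here, compound 1 holds the only actual number in the set, 32100 nM. Compound 2 and compound 3 each reach only a limit, so the set as a whole shows (the limit of > 100000 nM in this assay, at which 2 of the 3 values shown sit).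

Compound 4 `N#Cc1ccc(Cn2nc(-c3cc(Cl)c(NCCC(=O)O)nc3F)c3ccccc3c2=O)cc1` keeps the core of compound 1 and changes one group. It has carboxy in place of hydroxy on a saturated chain carbon, two bonds along the chain from a nitrogen on an aromatic ring, so (2-hydroxyethyl)amino becomes (2-carboxyethyl)amino (carboxy in place of hydroxy on a saturated chain carbon, two bonds along the chain from a nitrogen on an aromatic ring).

Going by the values given here, no measured pair of compounds shows this change, so any forecast in this assay is loose. A small move towards more compound being tolerated is expected, of a size near the usual scatter. That lean rests only on (the limit of > 100000 nM in this assay, at which 2 of the 3 values shown sit). The expected step is a 1.9-fold higher number from compound 1 to compound 4 (0.27 log units; within the scatter). For compound 4 the estimate is 60000 nM, with an expected range of 22000 nM to 100000 nM.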

Compound 4, half-maximal cytotoxic concentration: > 100000 nM
Compound 4: a limit, no number; the forecaster's own chance of this, stated with the estimate: 30%; middle value at least 1.6-fold (0.22 log units) away from the limit.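

In this assay, compound 4 gives > 100000 nM, which is a limit of the assay and not a number. For the compounds shown here, changing (2-hydroxyethyl)amino to (2-carboxyethyl)amino gives an at least 3.1-fold higher number from compound 1 to compound 4 (0.49 log units; beyond the scatter), so this is the first measured pair to show that a change at this chain end can alter how much compound the cells tolerate. Compound 1 is now the only compound in the set with an actual number: the limit of > 100000 nM in this assay, at which 3 of the 4 values shown sit.

The limit leaves the full size of this step unknown. As far as these compounds go, it also remains open whether a primary amine at the end of the chain, or a longer chain ending in carboxy, would move the result in the same way.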